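The compounds below may be only part of what the source reports. "The series", "measured", "known", "first", "only" and "open" are said of these compounds alone.

Within the data shown here, compound 3 `O=C(Nc1nn(-c2ccccc2)c(=O)c2ccccc12)c1ccco1` gives 23% in an assay on CHO cells for displacement of a labelled ligand from adenosine receptor A1 (Homo sapiens), tested at 10 uM (on this read-out lower numbers stand for less inhibition and higher numbers for more inhibition at the one concentration tested (going by the name of the read-out)), and stands highest of the three numbers measured so far. Compound 1 `O=C(Nc1ccc(Cl)cc1)Nc1nn(-c2ccccc2)c(=O)c2ccccc12` gives 10% and compound 2 `COc1ccccc1NC(=O)Nc1nn(-c2ccccc2)c(=O)c2ccccc12` gives 0%. The step of a number 10 percentage points lower from compound 1 to compound 2 (within the scatter) lies within the scatter, so the two arylamino variants are not separated on this read-out. Against both of them the furan-2-yl compound is set apart: a number 13 percentage points higher from compound 1 to compound 3 (beyond the scatter) and a number 23 percentage points higher from compound 2 to compound 3 (beyond the scatter), both modest gains.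

Compound 4 `O=C(Nc1ccccc1)Nc1nn(-c2ccccc2)c(=O)c2ccccc12` is not yet measured. It differs from compound 3 in one place: anilino in place of furan-2-yl on a carbonyl carbon. This runs opposite to the two measured steps, which both replaced an arylamino group by furan-2-yl on the same carbonyl carbon and both gained. Among the measured compounds shown here, no measured step covers the unsubstituted anilino group itself; compounds 1 and 2 carry a substituted phenyl ring on the amide-type nitrogen. The expectation is therefore a modest fall back toward the values of compounds 1 and 2, because a number 13 percentage points higher from compound 1 to compound 3 (beyond the scatter) and a number 23 percentage points higher from compound 2 to compound 3 (beyond the scatter) were both gains when an arylamino group left the carbonyl carbon. The estimate for compound 4 is 8%, between 0% and 22%. This corresponds to an expected step of a number 15 percentage points lower from compound 3 to compound 4 (beyond the scatter).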

Compound 4, a percentage reported as inhibition, at one concentration (the size of the read-out at that concentration, not a potency): 44%
For compound 4 the middle estimate is 36 percentage points below the measured one, outside the stated range (above it).
By their numbers in this assay, from the lowest: compounds 2 and 1 (each within the scatter of the next); then compound 3; then compound 4.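

In this assay the step of a number 21 percentage points higher from compound 3 to compound 4 (beyond the scatter) shows that an arylamino group on this carbonyl carbon does not by itself go with a low number: the unsubstituted anilino group stands above furan-2-yl, against the direction of the two earlier steps at this place. The substituent on the phenyl ring of the anilino group now appears as the larger variable, with a number 44 percentage points higher from compound 2 to compound 4 (beyond the scatter) for the loss of methoxy and a number 34 percentage points higher from compound 1 to compound 4 (beyond the scatter) for the loss of chloro, both larger than the change of furan-2-yl to anilino. No measured data here account for the higher number of the unsubstituted ring or for the drop with either substituent.

With one example each of chloro and methoxy, the compounds shown do not settle whether any group on this phenyl ring lowers the number, or whether fluoro or methyl would behave in the same way. Also open, as far as these compounds go, are how a saturated amine such as piperidine on the same carbonyl carbon would compare with anilino, and what potency lies behind these single-concentration percentages.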